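Swapping the amide nitrogen group in a 5-lipoxygenase series

The compounds below may be only part of what the source reports. "The series", "measured", "known", "first", "only" and "open" are said of these compounds alone.

Compound 1 `CCCOc1cc(C)c2c(c1C)CC(C(C)C(=O)NCc1cccs1)CC2`: 8000 nM
Compound 2 `COc1cc(C)c2c(c1C)CC(C(C)C(=O)NC(C)(C)C)CC2`: a limit of the assay, > 10000 nM
Compound 3 `COc1cc(C)c2c(c1C)CC(C(C)C(=O)NCc1cccs1)CC2`: 8000 nM

In a functional assay for inhibition of Polyunsaturated fatty acid 5-lipoxygenase (Homo sapiens) (on this read-out higher numbers stand for weaker inhibition and lower numbers for stronger inhibition), compound 1 gives 8000 nM, level with compound 3, so that no change at the digits printed from compound 1 to compound 3 (within the scatter). For the measured compounds named here, on the amide nitrogen, the one measured step is an at least 1.2-fold lower number from compound 2 to compound 3 (0.09 log units; that floor lies within the scatter); its upper end sits at the limit of > 10000 nM in this assay, at which 1 of the 3 values shown sits, so its true size is unknown. Compound 4 `CCCOc1cc(C)c2c(c1C)CC(C(C)C(=O)Nc1ncc(C)s1)CC2` is not yet measured and differs from compound 1 by 5-methyl-1,3-thiazol-2-yl in place of (thiophen-2-yl)methyl on an amide-type nitrogen. The measured nitrogen step gives no size to lean on, so no step beyond the scatter is expected. Compound 4 is therefore estimated at 8000 nM, between 2500 nM and 25000 nM. The expected step is no change at the digits printed from compound 1 to compound 4 (within the scatter).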

Compound 4, half-maximal inhibitory concentration: 1000 nM
The estimate for compound 4 lay 8.0-fold (0.90 log units) above the measured number, outside the stated range (below it).
By their numbers in this assay, from the lowest: compound 4; then compounds 1 and 3 (each within the scatter of the next). At a limit, above all of these: compound 2.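

In this assay, the group on the amide-type nitrogen proves able to move the number beyond the scatter, with 5-methyl-1,3-thiazol-2-yl in place of (thiophen-2-yl)methyl: an 8.0-fold lower number from compound 1 to compound 4 (0.90 log units; beyond the scatter). The earlier compounds shown here had given this position no step of readable size. Nothing measured here accounts for the step.

The compounds shown leave open whether an unmethylated 1,3-thiazol-2-yl or a thiophen-2-yl set directly on the amide nitrogen would keep the lower number. From the compounds shown here alone, whether a pyridin-2-yl would do the same also remains open.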